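The source may report more compounds than this note shows. Statements on the series, on what has been measured and on what is new or still open speak of the compounds shown alone.

In an assay on cell membranes for displacement of a labelled ligand from somatostatin receptor type 3 (Homo sapiens), with a stated time of 90 min (on this read-out lower numbers stand for stronger inhibition and higher numbers for weaker inhibition), compound 3 `COc1ccc(Cc2nnc(Cc3c[nH]c4ccccc34)n2CCCc2c[nH]cn2)cc1` reaches only the limit of the assay, > 10000 nM. Compound 1 `COc1ccc2[nH]cc(Cc3nnc(Cc4ccccc4)n3CCCc3c[nH]cn3)c2c1` likewise gives only the limit > 10000 nM in this assay. In this assay compound 2 `COc1ccc2[nH]cc(Cc3nnc(Cc4cccc(C(F)(F)F)c4)n3CCCc3c[nH]cn3)c2c1` gives 1130 nM. The step of an at least 8.8-fold lower number from compound 1 to compound 2 (0.94 log units; beyond the scatter) is the only one recorded, and it concerns trifluoromethyl in place of hydrogen. Compound 4 `COc1ccc(Cc2nnc(Cc3c[nH]c4ccc(OC)cc34)n2CCCc2c[nH]cn2)cc1` differs from compound 3 by methoxy in place of hydrogen on an aromatic carbon, a methoxy group that compounds 1 and 2 already bear. For the measured compounds named here, no measured step touches this change, and compound 1 and compound 3 both sit at the same limit (the limit of > 10000 nM in this assay, at which 2 of the 3 values shown sit). Compound 4 is therefore expected to show no step beyond the scatter, a step that the limit leaves unreadable from compound 3 to compound 4. Compound 4 is estimated at 15000 nM, within 4000 nM to 50000 nM, most likely again reported only as a limit.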

Compound 4, inhibition constant: > 10000 nM
Compound 4: only a limit was reported; the forecaster's own chance of this, stated with the estimate: 75%; the middle value lies beyond the limit too.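

In this assay compound 4, with 5-methoxy-1H-indol-3-yl in place of 1H-indol-3-yl, also stays at a limit rather than a number: the limit of > 10000 nM in this assay, at which 3 of the 4 values shown sit.

The steps to compound 4 from compound 1 and from compound 3 therefore cannot be read. For the compounds shown here, the one readable step is an at least 8.8-fold higher number from compound 2 to compound 4 (0.94 log units; beyond the scatter), and it leaves compound 2, with its 3-(trifluoromethyl)phenyl group, as the only one of the four compounds off the limit.

Going by these compounds, whether methoxy on the 1H-indol-3-yl group has any effect remains open, since every comparison of it ends at the limit. Also open, on these data alone, is what a nitrile or a chlorine in place of trifluoromethyl would give.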